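The compounds below may be only part of what the source reports. "The series", "measured", "known", "first", "only" and "open" are said of these compounds alone.

Measured in an assay on CHO cells for agonist activity at Free fatty acid receptor 1 (Homo sapiens), read by luminescence, with a stated time of 20 s, in the presence of a further agent that is not named here; on this read-out lower numbers stand for an effect already at smaller amounts and higher numbers for an effect only at larger amounts of compound:
compound 1 `Cc1cc(Cl)ccc1-c1cccc(COc2ccc([C@H](CC(=O)O)c3nccn3C)cc2)c1C`: 240 nM
compound 2 `Cn1ccnc1[C@@H](CC(=O)O)c1ccc(OCc2cccc(-c3ccc(Cl)cc3Cl)c2)cc1`: 69 nM
compound 3 `Cc1ccc(F)cc1-c1cccc(COc2ccc([C@H](CC(=O)O)c3nccn3C)cc2)c1`: 36 nM

Compound 3 stands below compound 1 beyond the scatter; compound 2 lies within the scatter of compound 3, so no order between those two is claimed. Compound 4 `Cc1cccc(C)c1-c1cccc(COc2ccc([C@H](CC(=O)O)c3nccn3C)cc2)c1` has not yet been measured. The change is 2,6-dimethylphenyl in place of 5-fluoro-2-methylphenyl on an aromatic carbon. For the measured compounds named here, the only measured step that touches this part of the molecule is a 1.9-fold lower number from compound 2 to compound 3 (0.28 log units; within the scatter), an aryl swap that stayed within the scatter. Compound 1 differs from compound 3 in two places, so its higher number gives no single-change reading. Expected for compound 4 in this assay is therefore a step of a 1.7-fold higher number from compound 3 to compound 4 (0.22 log units; within the scatter), not beyond the scatter. The estimate for compound 4 is 60 nM, range 20 nM to 180 nM.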

Compound 4, half-maximal effective concentration: 58 nM
Compound 4: the middle estimate sits 1.0-fold (0.01 log units) above what was measured, within the range that was stated.
By their numbers in this assay, from the lowest: compounds 3, 4 and 2 (each within the scatter of the next); then compound 1.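

In this assay, 2,6-dimethylphenyl in place of 5-fluoro-2-methylphenyl gives a 1.6-fold higher number from compound 3 to compound 4 (0.21 log units; within the scatter), and in place of 2,4-dichlorophenyl it gives a 1.2-fold lower number from compound 2 to compound 4 (0.08 log units; within the scatter). Across compounds 2, 3 and 4, this aromatic carbon therefore carries three differently substituted phenyl groups, including one with only carbon as its heavy atoms, with no separation beyond the scatter. No available evidence bears on this result.

Still open, from the compounds shown here alone, is whether a phenyl group carrying an amine or a carboxylic acid at this place would stay within the same scatter.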